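Swapping methyl for methoxy on a weakly cytotoxic pair

A few compounds are considered here, and "the series" means these few. Any claim that something is new, unique, unknown or untested is made for them only; others in the source may bear on it.

Of the compounds shown here, three have been tested in a functional assay on MCF7 cells (Homo sapiens) for cytotoxicity, read by sulforhodamine B assay, with a stated time of 72 h; on this read-out lower numbers stand for stronger inhibition and higher numbers for weaker inhibition. Compound 1 `CC(=O)c1nn(-c2ccc(C)cc2)/c(=N/c2nc(-c3c(C)n(C)n(-c4ccccc4)c3=O)cs2)s1` gives 56800 nM. Compound 2 `COc1ccc(-n2nc(C(C)=O)s/c2=N\c2nc(-c3c(C)n(C)n(-c4ccccc4)c3=O)cs2)cc1` gives 64500 nM in this assay. For compound 3 `CCOC(=O)c1nn(-c2ccc(C)cc2)/c(=N/c2nc(-c3c(C)n(C)n(-c4ccccc4)c3=O)cs2)s1` this assay reports only a limit, > 100000 nM, and not a number; the value sits at the limit of > 100000 nM in this assay, at which 1 of the 3 values shown sits.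

The change from compound 1 to compound 2 is methoxy in place of methyl on an aromatic carbon, and the step it made was a 1.1-fold higher number from compound 1 to compound 2 (0.06 log units; within the scatter). Compound 3 differs from compound 1 in its core by ethoxy in place of methyl on a carbonyl carbon; the step was an at least 1.7-fold higher number from compound 1 to compound 3 (0.24 log units; that floor lies within the scatter), and because the limit of > 100000 nM in this assay, at which 1 of the 3 values shown sits, holds for compound 3, only a floor of that step is known.

Compound 4 `CCOC(=O)c1nn(-c2ccc(OC)cc2)/c(=N/c2nc(-c3c(C)n(C)n(-c4ccccc4)c3=O)cs2)s1` has not yet been measured in this assay. It relates to compound 3 exactly as compound 2 relates to compound 1: the change is methoxy in place of methyl on an aromatic carbon, made at the same place as before, so it is the same change on the other core. Between compound 1 and compound 2 this change stayed within the scatter, and the same small movement is expected here, so that the step from compound 3 to compound 4 is estimated at a step that the limit leaves unreadable from compound 3 to compound 4. Since compound 3 already sits at a limit, compound 4 is expected to give about 120000 nM, with a likely range from 60000 nM to 300000 nM, and most probably this assay will again report only a limit for compound 4.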

Compound 4, half-maximal inhibitory concentration: 15900 nM
Compound 4: the middle estimate sits 7.5-fold (0.88 log units) above what was measured; measured number outside the range, below it.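

In this assay, the change from 4-methylphenyl to 4-methoxyphenyl did not carry over unchanged from one core to the other; with ethoxy on the carbonyl carbon it gave an at least 6.2-fold lower number from compound 3 to compound 4 (0.79 log units; beyond the scatter), and this differs clearly from the step with methyl on that carbon: the same change on two cores in this assay, a 1.1-fold higher number (0.06 log units; within the scatter) from compound 1 to compound 2 and an at least 6.2-fold lower number (0.79 log units; beyond the scatter) from compound 3 to compound 4, at least 7.1-fold (0.85 log units) apart, beyond the scatter of two such steps

The same gap appears when the pairs are read the other way, as ethoxy in place of methyl on a carbonyl carbon gave a 4.1-fold lower number from compound 2 to compound 4 (0.61 log units; beyond the scatter) with the 4-methoxyphenyl group present, while the step with the 4-methylphenyl group points the other way: the same change on two cores in this assay, an at least 1.7-fold higher number (0.24 log units; that floor lies within the scatter) from compound 1 to compound 3 and a 4.1-fold lower number (0.61 log units; beyond the scatter) from compound 2 to compound 4, at least 7.1-fold (0.85 log units) apart, beyond the scatter of two such steps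

Compound 3 gives > 100000 nM, which is a limit and not a number, and so only a floor of its steps is known; these four compounds show that the outcome of the swap depends on the group on the carbonyl carbon in this series, but they do not show why, nor how large the true step is.

As far as these compounds go, it remains open how the swap would behave with another group on that carbonyl carbon, such as an amine or a hydroxyl group. From the compounds shown here alone, it also remains open whether a different group on the aromatic ring, such as chloro or a longer alkoxy chain, would follow compound 4 or compound 2.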